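Isopropyl to tert-Butyl on a Triazole Nucleoside Core

The compounds below may be only part of what the source reports. "The series", "measured", "known", "first", "only" and "open" are said of these compounds alone.

Compound 1 `CC(=O)OC[C@H]1O[C@@H](n2cc(-c3cn(Cc4ccc(C(C)C)cc4)nn3)c(=O)[nH]c2=O)C[C@@H]1OC(C)=O` gives 91.3%
Compound 2 `CC(C)(C)c1ccc(-c2cc(-c3cn([C@H]4C[C@H](O)[C@@H](CO)O4)c(=O)[nH]c3=O)on2)cc1` gives 87.9%
Compound 3 `CC(=O)OC[C@H]1O[C@@H](n2cc(-c3cc(C)no3)c(=O)[nH]c2=O)C[C@@H]1OC(C)=O` gives 92.4%

In a functional assay on PC-3 cells (Homo sapiens) for cytotoxicity, read by sulforhodamine B assay, tested at 10 uM (on this read-out lower numbers stand for less inhibition and higher numbers for more inhibition at the one concentration tested (going by the name of the read-out)), compound 1 holds the second highest of the three numbers, yet the gap to compound 3 above it and the gap to compound 2 below it both fall within the scatter, so the three compounds cannot be told apart on these readings.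

Compound 4 `CC(=O)OC[C@H]1O[C@@H](n2cc(-c3cn(Cc4ccc(C(C)(C)C)cc4)nn3)c(=O)[nH]c2=O)C[C@@H]1OC(C)=O` differs from compound 1 by a single change: methyl in place of hydrogen on a saturated chain carbon bound to an aromatic carbon and two saturated chain carbons. Within the data shown here, no pair of measured compounds shows this kind of change, so there is no measured step to lean on. The estimate for compound 4 is 90% with a range of 80% to 97%, and the expected step of a number 1.3 percentage points lower from compound 1 to compound 4 (within the scatter) is one that stays within the scatter in either direction.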

Compound 4, a percentage reported as inhibition, at one concentration (the size of the read-out at that concentration, not a potency): 90.4%
The estimate for compound 4 lay 0.4 percentage points below the measured number; the range from low to high includes it.
By their numbers in this assay, from the lowest: compounds 2, 4, 1 and 3 (each within the scatter of the next).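

In this assay, among these compounds, replacing isopropyl with tert-butyl gives a number 0.9 percentage points lower from compound 1 to compound 4 (within the scatter), the first measured step at this position. At the single concentration tested, this added methyl on the saturated chain carbon therefore produces no change that can be told from scatter. Nothing measured here offers an explanation for this result.

The compounds shown leave open whether an amine or a carboxylic acid in place of the tert-butyl would shift the reading beyond the scatter. A reading at one concentration also leaves open whether compound 1 and compound 4 differ in potency.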